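From Isobutyl to Isopropylamino on a Carbonyl Carbon

The compounds below may be only part of what the source reports. "The series", "measured", "known", "first", "only" and "open" are said of these compounds alone.

Compound 1, `CC1=C(C(=O)CC(C)C)C(c2ccco2)NC(=O)N1`, gives 31%
Compound 2, `CC1=C(C(=O)CC(C)C)C(c2ccsc2)NC(=O)N1`, gives 14%

Both numbers come from an assay on membranes from HeLa cells for displacement of a labelled ligand from adenosine receptor A3 (Homo sapiens), read by scintillation counting, with a stated time of 180 min, tested at 1 uM (on this read-out lower numbers stand for less inhibition and higher numbers for more inhibition at the one concentration tested (going by the name of the read-out)), at a single concentration. Among the measured compounds shown here, the one measured step, a number 17 percentage points lower from compound 1 to compound 2 (beyond the scatter), goes with thiophen-3-yl in place of furan-2-yl on a saturated ring carbon. Compound 2 therefore stands lowest of the two numbers, and compound 1 lies higher by a margin beyond the scatter.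

Compound 3, `CC1=C(C(=O)NC(C)C)C(c2ccsc2)NC(=O)N1`, differs from compound 2 by isopropylamino in place of isobutyl on a carbonyl carbon and is not yet measured. For the measured compounds named here, no measured step bears on this part of the shared core: the only known step changes the ring on the saturated ring carbon and leaves the carbonyl side untouched. The numbers thus give no direction for this change, and the expected step of a number 2 percentage points lower from compound 2 to compound 3 (within the scatter) is none beyond the scatter, with a wide range to allow for the unknown. In this assay compound 3 is expected to give 12%, somewhere between 0% and 35%.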

Compound 3, a percentage reported as inhibition, at one concentration (the size of the read-out at that concentration, not a potency): 1%
Compound 3: the middle estimate sits 11 percentage points above what was measured, within the range that was stated.
By their numbers in this assay, from the lowest: compound 3; then compound 2; then compound 1.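

In this assay, isopropylamino in place of isobutyl on a carbonyl carbon goes with a number 13 percentage points lower from compound 2 to compound 3 (beyond the scatter), so this side of the shared core, which the earlier step left untouched, does respond to the group placed on it. The two groups have the same count of heavy atoms: one carbon gives way to a nitrogen, and the entering group brings in one hydrogen-bond donor, so this step goes with that exchange and not with a difference in heavy-atom count. Nothing available here explains why the number falls with this change.

Going by these compounds, whether isopropylamino would go with a similar step when furan-2-yl takes the place of thiophen-3-yl remains open. Also open, on these data alone, is how other groups on this carbonyl carbon would read, such as dimethylamino, which has no amide hydrogen, methoxy, which would make an ester, or a longer chain such as n-pentyl.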